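The source may report more compounds than this note shows. Statements on the series, on what has been measured and on what is new or still open speak of the compounds shown alone.

Measured compounds:
- compound 1, `CC(C)(C)c1ccc(CNC(=O)Nc2cccc3cnccc23)cc1`, 13.8 nM
- compound 2, `CC1CCN(c2nc(C(F)(F)F)ccc2CNC(=O)Nc2ccc3cccnc3c2)CC1`, 7.1 nM

Both compounds were tested in an assay on isolated protein for antagonist activity at transient receptor potential cation channel subfamily V member 1 (Homo sapiens), read by FLIPR; a higher number here means a weaker inhibitor, a lower number a stronger inhibitor. Compound 2 gives the lower of the two numbers, but its gap to compound 1 lies within the usual scatter of repeated measurements, so the two cannot be told apart on these data. Compound 3, `CC1CCN(c2nc(C(F)(F)F)ccc2CNC(=O)Nc2ccc3ccncc3c2)CC1`, has not yet been measured. It differs from compound 2 in one place only: isoquinolin-7-yl in place of quinolin-7-yl on an amide-type nitrogen. The two compounds share every atom and differ only in how those atoms are joined. Among the measured compounds shown here, no measured pair shows what such a change does, so no direction can be read from the data. Compound 3 is therefore expected to land near compound 2, with a step of a 1.4-fold higher number from compound 2 to compound 3 (0.15 log units; within the scatter) that stays within the scatter. Compound 3 is estimated at 10 nM, with a range from 3 nM to 40 nM.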

Compound 3, inhibition constant: 8.4 nM
For compound 3 the middle estimate is 1.2-fold (0.08 log units) above the measured one, within the range that was stated.
By their numbers in this assay, from the lowest: compounds 2, 3 and 1 (each within the scatter of the next).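

Placing isoquinolin-7-yl in place of quinolin-7-yl on an amide-type nitrogen gives a 1.2-fold higher number from compound 2 to compound 3 (0.07 log units; within the scatter) in this assay, so the two groups cannot be told apart at this position. The earlier compounds shown here offered no pair differing in this way; this pair shows that, here, the same atoms can be joined in these two ways without a difference that exceeds the scatter. Nothing available explains this result.

Still open, going by these compounds, is how a group with a carbon-only ring system, such as naphthyl, or a smaller one, such as plain phenyl, would read at this same place, which would show whether the ring nitrogen matters at all. On these data alone, it is also open whether this exchange would give a similar result with the other parts of the molecule changed, for example with piperidine lacking its methyl group.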